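Adding a Methoxy Group to a Weak Inhibitor Series

This account rests on a few compounds, and the source may have more. Where it says the series, first, only, none or still open, it means among the compounds named here.

Compound 1 `Oc1ccccc1/C=N/c1ccc(OCc2ccccc2)cc1` is the parent of this small set. For the measured compounds named here, in an assay on isolated protein for inhibition of Amine oxidase [flavin-containing] B (Homo sapiens), read by fluorescence and Amplex Red, with stated times of 15 min and 20 min (on this read-out higher numbers stand for weaker inhibition and lower numbers for stronger inhibition), compound 1 gives 25100 nM, the highest of the three numbers so far, though the other two lie within the scatter of it. Compound 2 `Cc1ccc(O)c(/C=N/c2ccc(OCc3ccccc3)cc2)c1` carries a methyl in place of a hydrogen on an aromatic carbon, and in this assay compound 2 gives 24600 nM. Compound 3 `Oc1ccc(Cl)cc1/C=N/c1ccc(OCc2ccccc2)cc1` carries a chloro in place of a hydrogen on an aromatic carbon, and in this assay compound 3 gives 24800 nM. The steps of a 1.0-fold lower number from compound 1 to compound 2 (0.01 log units; within the scatter) and a 1.0-fold lower number from compound 1 to compound 3 (0.01 log units; within the scatter) are both within the scatter, as is a 1.0-fold higher number from compound 2 to compound 3 (0.00 log units; within the scatter).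

Compound 4 `COc1cccc(/C=N/c2ccc(OCc3ccccc3)cc2)c1O` has not been measured. It differs from compound 1 by methoxy in place of hydrogen on an aromatic carbon. The two measured changes on an aromatic carbon of compound 1, a 1.0-fold lower number from compound 1 to compound 2 (0.01 log units; within the scatter) and a 1.0-fold lower number from compound 1 to compound 3 (0.01 log units; within the scatter), bear on this step, and neither moved the number beyond the scatter. No step beyond the scatter is therefore expected, the estimated step being a 1.0-fold lower number from compound 1 to compound 4 (0.00 log units; within the scatter). Compound 4 is expected to give 25000 nM, within a range from 12000 nM to 52000 nM.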

Compound 4, half-maximal inhibitory concentration: 6500 nM
Estimate against measurement, compound 4: 3.8-fold (0.59 log units) above; the measured number lies below the stated range.
By their numbers in this assay, from the lowest: compound 4; then compounds 2, 3 and 1 (each within the scatter of the next).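

In this assay, the methoxy ortho to a hydroxy group gives a 3.9-fold lower number from compound 1 to compound 4 (0.59 log units; beyond the scatter), a modest step, but the first in this set to lie beyond the scatter. The methyl of compound 2 and the chloro of compound 3 left the number within the scatter of compound 1, so the earlier flat picture does not hold for every change on this ring: a methoxy on this carbon does lower the number. Nothing measured here gives a reason for this step.

Going by these compounds, only methoxy stands on this carbon, so it remains open whether an ethoxy, an amine or a simple fluoro there would lower the number as well. On these data alone, it is equally open whether methoxy needs this particular carbon, or would give a similar step on the carbon that carries the chloro in compound 3.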